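Swapping Acetoxy for Benzoyloxy: What to Expect

The source may hold more compounds than are shown below. What is called first, only, known or untested is meant among the compounds shown, and "the series" means these compounds.

In a functional assay on SMMC-7721 cells (Homo sapiens) for antiproliferative activity, read by MTT assay, with a stated time of 48 h (on this read-out higher numbers stand for weaker inhibition and lower numbers for stronger inhibition), compound 3 `CC(=O)O[C@@H]1/C=C/[C@@](C)(CCC=C(C)C)C/C=C(/CO)C(=O)/C=C/[C@@]1(C)O` gives 9870 nM. Compound 2 `CO/N=C/C1=C/C[C@](C)(CCC=C(C)C)/C=C/[C@@H](OC(=O)C=C(C)C)[C@](C)(O)/C=C/C1=O` gives 3470 nM, a lower number, and this gap lies beyond the usual scatter of repeated measurements. Compound 3 therefore holds the higher of the two actual numbers available. Compound 1 `CC(C)=CCC[C@]1(C)/C=C/[C@@H](OC(=O)C=C(C)C)[C@](C)(O)/C=C/[C@H](O)/C(CO)=C\C1` gives > 40000 nM, which is a limit of this assay and not a number.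

Compound 4 `CC(C)=CCC[C@]1(C)/C=C/[C@@H](OC(=O)c2ccccc2)[C@](C)(O)/C=C/C(=O)/C(CO)=C\C1` has not yet been measured. It differs from compound 3 in one place: phenyl in place of methyl on a carbonyl carbon. Put another way, acetoxy becomes benzoyloxy. Within the data shown here, no pair of measured compounds shows this change on its own, so any forecast here is loose. Compound 2, at 3470 nM, shows only that a number lower than that of compound 3 does occur among these compounds. On that basis, a modest move towards stronger inhibition is expected, one that may well stay within the scatter. The estimated change is a 1.6-fold lower number from compound 3 to compound 4 (0.22 log units; within the scatter). For compound 4 the estimated value is 6000 nM, with an expected range from 1800 nM to 20000 nM.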

Compound 4, half-maximal inhibitory concentration: 20300 nM
Beside the measured number, compound 4's estimate is 3.4-fold (0.53 log units) below it; measured number above the stated range.
By their numbers in this assay, from the lowest: compound 2; then compound 3; then compound 4. At a limit, above all of these: compound 1.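

Replacing methyl with phenyl on this carbonyl carbon gives, in this assay, a 2.1-fold higher number from compound 3 to compound 4 (0.31 log units; beyond the scatter), so the change from acetoxy to benzoyloxy modestly weakens inhibition here. Among these compounds, this is the first measured pair that differs only at this place, and it shows that the position is not indifferent to what the carbonyl carbon carries, even though the step is only just beyond the usual scatter. It also shows that adding one six-membered aromatic ring of carbon only does not improve on methyl in this pair, yet nothing measured for these compounds explains why the number rises.

The compounds shown compare only methyl and phenyl at this place, so one pair cannot show a trend, and it remains open whether a longer chain such as propyl, or a phenyl ring carrying an amine, would fall nearer compound 3 or compound 4. From the compounds shown here alone, it also remains open whether the same swap would give a similar step on a compound that differs elsewhere in the shared core.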